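From cyclohexylamino to a charged six-membered ring

The compounds below may be only part of what the source reports. "The series", "measured", "known", "first", "only" and "open" are said of these compounds alone.

In a functional assay (aorta) with Rattus norvegicus as the target (a lower number here means that less compound is needed, a higher number that more compound is needed for the effect), compound 1 `COc1ccc(-c2nc(N=C(N)N)sc2-c2ccc(OC)cc2)cc1` gives 2 uM as a measured number. Compound 2 `COc1ccc(-c2nc(/N=C(\N)NC3CCCCC3)sc2-c2ccc(OC)cc2)cc1` gives > 100 uM as a limit of the assay and not a number. Compound 2 thus stands at the limit of > 100 uM in this assay, at which 1 of the 2 values shown sits, and has no exact value.

Compound 3 `COc1ccc(-c2nc(/N=C(\N)[N+]3(C)CCCCC3)sc2-c2ccc(OC)cc2)cc1` has not been measured yet. It loses the cyclohexylamino group and gains, on a carbon with a double bond to nitrogen, a six-membered non-aromatic ring with 1 hetero atom and net charge +1 a group of 7 heavy atoms (6 carbon, 1 nitrogen; one six-membered non-aromatic ring with 1 hetero atom) in place of a group of 7 heavy atoms (6 carbon, 1 nitrogen; one six-membered non-aromatic ring of carbon only), on a carbon with a double bond to nitrogen in exchange.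

Among the measured compounds shown here, the only measured step that bears on this is an at least 50-fold higher number from compound 1 to compound 2 (1.69 log units; beyond the scatter) with cyclohexyl in place of hydrogen on an amine nitrogen. Compound 3 keeps a six-membered ring in that place, so a return towards compound 1 at 2 uM is not expected. For the measured compounds named here, no measured step changes the net charge, so the range stays wide. The expected change is a number no higher from compound 2 to compound 3 (the limit leaves the size open) in this assay and nothing beyond the scatter is expected. Compound 3 is expected at 100 uM within an estimated range from 20 uM to 300 uM as the working estimate.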

Compound 3, concentration for half-maximal effect: 21 uM
Compound 3: middle estimate off by 4.8-fold (0.68 log units), on the high side; the measured number falls inside the stated range.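

Putting the charged six-membered ring in place of cyclohexylamino gives an at least 4.7-fold lower number from compound 2 to compound 3 (0.67 log units; beyond the scatter) in this assay, even though the entering and leaving groups have the same heavy-atom count. A large ring on this carbon with a double bond to nitrogen therefore does not always push the number to the top of what the read-out can report. The recovery is only partial, since an 11-fold higher number from compound 1 to compound 3 (1.02 log units; beyond the scatter) remains in this assay, and the true size of the first step stays open, as compound 2 has only a limit of the assay and not a number: the limit of > 100 uM in this assay, at which 1 of the 3 values shown sits.

Compound 3 differs from compound 2 both in its net charge of +1 and in having no hydrogen-bond donor in this group, so the compounds shown cannot separate these two changes, or either of them from the altered ring. A methylamino group or a morpholine ring on the same carbon would add evidence on how much of the step depends on the size of the group and how much on the kind of ring.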